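Cytotoxicity notes on compounds 2 and 4 in the series

The source may report more compounds than this note shows. Statements on the series, on what has been measured and on what is new or still open speak of the compounds shown alone.

Of the compounds shown here, three have been read in an ADME assay on cells (Homo sapiens) for cytotoxicity, read by resazurin assay, with a stated time of 5 days; a higher number here means that more compound is tolerated, a lower number that less compound is tolerated. Compound 1 `CCC1=C(C(=O)OCC2CCCCC2)C(c2cccc(O)c2)NC(=O)N1` does not yield a number: in this assay compound 1 gives > 10000 nM, which is a limit of the assay, as recorded in the limit of > 10000 nM in this assay, at which 1 of the 3 values shown sits. Compound 2 `COc1ccc(-c2nc(CC(=O)c3cccc(Cl)c3)nc3ccsc23)cn1` gives 30000 nM in this assay. Compound 3 `COc1ccc(-c2nc(CS(=O)(=O)c3cccc(Cl)c3)nc3ccsc23)cc1` gives 69000 nM in this assay. Of the two numbers available, compound 2 stands lowest, and the gap up to compound 3, its nearest neighbour, lies beyond the usual scatter; compound 1 contributes only a limit and cannot be ranked.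

Compound 4 `COc1ccc(-c2nc(CSc3ccc(F)cc3F)nc3ccsc23)cn1` is not yet measured. Its difference from compound 2 is confined to one place:
(2,4-difluorophenyl)sulfanyl in place of (3-chlorophenyl)carbonyl on a saturated chain carbon bound to an aromatic carbon
Going by the values given here, no measured pair in the set isolates this change, so the data give no established direction for it. Among the compounds with values here, the expected step is no change at the digits printed from compound 2 to compound 4 (within the scatter), that is, none beyond the scatter, because compound 2 gives 30000 nM in this assay and no measured pair isolates the change from it. Compound 4 is accordingly estimated at 30000 nM in this assay. The plausible range for compound 4 is expected to run from 10000 nM to 90000 nM.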

Compound 4, half-maximal cytotoxic concentration: > 50000 nM
Compound 4 gave a limit, no number; the forecaster's own chance of this, stated with the estimate: 25%; middle value at least 1.6-fold (0.22 log units) away from the limit.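

Going by these compounds alone, this is the first step read at this position, on a saturated chain carbon bound to an aromatic carbon, and it shows that (2,4-difluorophenyl)sulfanyl in place of (3-chlorophenyl)carbonyl brings no measured fall in the number, with an at least 1.6-fold higher number from compound 2 to compound 4 (0.22 log units; that floor lies within the scatter). In this assay compound 4 gives > 50000 nM, which is a limit of the assay and not a number. The step therefore has a floor and no top, and that floor alone does not establish a change beyond the scatter, so its true size stays unknown: the limit of > 50000 nM in this assay, at which 1 of the 4 values shown sits.

The step exchanges the sulfur-containing link for the carbonyl and the two fluorines for the chlorine at once, so the compounds shown do not tell how much of it belongs to the link and how much to the ring substituents; (3-chlorophenyl)sulfanyl on the same carbon would separate the two. Going by these compounds, how this position responds to an amine or a carboxylic acid in place of these aryl groups also remains open, as does any reading of compound 4 as a number rather than a limit.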